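Replacing a ring-nitrogen substituent in a piperidine amide series

This account rests on a few compounds, and the source may have more. Where it says the series, first, only, none or still open, it means among the compounds named here.

Compound 1 `CC(C)(C)c1cc(NC(=O)[C@@H]2CCCCN2CC2CCOCC2)no1` is the weaker of the two measured compounds in an ADME assay (liver) for metabolic stability, with Liver microsome (Homo sapiens) as the target, read by LC-MS, using microsomes and NADPH, tested at 1 uM (on this read-out lower numbers stand for a shorter-lived compound and higher numbers for a longer-lived compound), where compound 1 gives 0.183 h. Going by the values given here, its only measured neighbour, compound 2 `CC(C)(C)c1cc(NC(=O)[C@@H]2CCCCN2C(=O)CC2CCOCC2)no1`, gives 1.83 h in this assay, a step of a 10-fold higher number from compound 1 to compound 2 (1.00 log units; beyond the scatter). The unmeasured compound 3 `CC(C)(C)c1cc(NC(=O)[C@@H]2CCCCN2C(=O)N2CC[S+]([O-])CC2)no1` differs from compound 1 in one place: a group of 9 heavy atoms (5 carbon, 1 nitrogen, 2 oxygen, 1 sulfur; one six-membered non-aromatic ring with 2 hetero atoms) in place of a group of 7 heavy atoms (6 carbon, 1 oxygen; one six-membered non-aromatic ring with 1 hetero atom), on an amine nitrogen in a ring. Among the compounds with values here, the one measured step that bears on this change is the one from compound 1 to compound 2, where the same (oxan-4-yl)methyl group left the ring nitrogen and an incoming group carrying a double bond outside aromatic rings took its place, with a rise of a 10-fold higher number from compound 1 to compound 2 (1.00 log units; beyond the scatter). Compound 3 likewise exchanges that group for one with such a double bond, so a rise of about the same size is expected in this assay, namely an 8.2-fold higher number from compound 1 to compound 3 (0.91 log units; beyond the scatter). Compound 3 is therefore estimated at 1.5 h, with a range from 0.5 h to 4.5 h.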

Compound 3, half-life: > 2 h
Compound 3 was reported as a limit; the forecaster's own chance of this, stated with the estimate: 5%; at least 1.3-fold (0.12 log units) between middle value and limit.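

At this amine nitrogen in a ring, a second incoming group with a double bond outside aromatic rings also lengthens the half-life in this assay, with an at least 10-fold higher number from compound 1 to compound 3 (1.03 log units; beyond the scatter). The rise seen with compound 2 is therefore not tied to that one group, at least across these three compounds. On the carbonyl carbon, exchanging the oxane ring for the ring holding nitrogen and sulfur gives an at least 1.0-fold higher number from compound 2 to compound 3 (0.03 log units; that floor lies within the scatter), so no order between these two compounds can be drawn.

As far as these compounds go, the result for compound 3 is a limit of the assay, which leaves its actual half-life open: the limit of > 2 h in this assay, at which 1 of the 3 values shown sits. It also remains open whether a morpholine ring on the same carbonyl carbon, with oxygen in place of sulfur, would behave like compound 3.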